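Lactam ring change at the carbonyl: compound 2 to compound 3

The compounds below may be only part of what the source reports. "The series", "measured", "known", "first", "only" and "open" are said of these compounds alone.

Measured so far in a functional assay on NCI-H460 cells (Homo sapiens) for cytotoxicity; a lower number here means a stronger inhibitor, a higher number a weaker inhibitor
- Compound 1 (`O=C(CCCCC[C@H](NC(=O)[C@@H]1CCCC(=O)N1)C(=O)Nc1ccccc1)NO`) gives 2500 nM
- Compound 2 (`O=C(CCCCC[C@H](NC(=O)C1CCCNC1=O)C(=O)Nc1ccccc1)NO`) gives 5100 nM

Compound 2 (5100 nM) has the higher of the two numbers. Compound 3 (`O=C(CCCCC[C@H](NC(=O)C1CCNC1=O)C(=O)Nc1ccccc1)NO`) carries 2-oxopyrrolidin-3-yl in place of 2-oxopiperidin-3-yl on a carbonyl carbon. Going by the values given here, only one measured step bears on this, a modest change at the same carbonyl carbon (a 2.0-fold higher number from compound 1 to compound 2 (0.31 log units; beyond the scatter)), and it leaves the ring's size unchanged. In this assay a similar or smaller step is therefore expected, perhaps towards a slightly higher number, possibly none beyond the scatter. The estimated step is small (a 1.3-fold higher number from compound 2 to compound 3 (0.11 log units; within the scatter)). Compound 3 is estimated at 6500 nM (expected range 2500 nM to 16000 nM).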

Compound 3, half-maximal inhibitory concentration: 4000 nM
For compound 3 the middle estimate is 1.6-fold (0.21 log units) above the measured one; the measured number falls inside the stated range.
By their numbers in this assay, from the lowest: compounds 1, 3 and 2 (each within the scatter of the next, the first and the last beyond it).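

In this assay, the five-membered 2-oxopyrrolidin-3-yl and the six-membered 2-oxopiperidin-3-yl on the carbonyl carbon cannot be told apart (a 1.3-fold lower number from compound 2 to compound 3 (0.11 log units; within the scatter)), so ring size shows no effect at this position. Set against the 6-oxopiperidin-2-yl of compound 1, the 2-oxopyrrolidin-3-yl also stays within the scatter (a 1.6-fold higher number from compound 1 to compound 3 (0.20 log units; within the scatter)), although compound 1 and compound 2 lie beyond it. No evidence at hand explains these results. The compounds shown leave open how a ring without the lactam carbonyl, such as the amine piperidin-3-yl, or an open-chain carboxylic acid would read on this carbonyl carbon.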